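The compounds below may be only part of what the source reports. "The series", "measured", "known", "first", "only" and "open" are said of these compounds alone.

Compound 1 `O=S(=O)(NCCNc1nccc(-c2c(-c3cccc(F)c3)nc3sccn23)n1)c1ccc(F)cc1` is tested in a functional assay on A-375 cells (Homo sapiens) for cytotoxicity, read by MTT assay (a lower number here means a stronger inhibitor, a higher number a weaker inhibitor), where compound 1 gives 9450 nM. Among the three measured compounds this number is the second highest; the nearest is compound 3 `O=S(=O)(NCCCNc1nccc(-c2c(-c3cccc(F)c3)nc3sccn23)n1)c1ccccc1`, which gives 6600 nM, and the furthest is compound 2 `Cc1ccc(S(=O)(=O)NCCNc2nccc(-c3c(-c4cccc(F)c4)nc4sccn34)n2)cc1`, which gives 15400 nM. The step of a 1.6-fold higher number from compound 1 to compound 2 (0.21 log units; within the scatter) stays within the scatter, while the step of a 2.3-fold lower number from compound 2 to compound 3 (0.37 log units; beyond the scatter) is modest but beyond it.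

Compound 4 `O=C(NCCCNc1nccc(-c2c(-c3cccc(F)c3)nc3sccn23)n1)c1ccc(F)cc1` differs from compound 1 in one place: (((4-fluorophenyl)carbonyl)amino)methyl in place of ((4-fluorophenyl)sulfonyl)amino on a saturated chain carbon, two bonds along the chain from a nitrogen on an aromatic ring. Part of this change resembles the change from compound 1 to compound 3, whose step a 1.4-fold lower number from compound 1 to compound 3 (0.16 log units; within the scatter) was within the scatter. For the measured compounds named here, the exchange of the sulfonyl for the carbonyl has no counterpart among the measured steps, so no measurement here speaks to it. The expectation for compound 4 is therefore a step of a 1.4-fold lower number from compound 1 to compound 4 (0.13 log units; within the scatter) that stays within the scatter, though with a wide range given the untested part of the change. Compound 4 is estimated at 7000 nM, expected to fall between 2500 nM and 20000 nM.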

Compound 4, half-maximal inhibitory concentration: 14900 nM
The estimate for compound 4 lay 2.1-fold (0.33 log units) below the measured number; the measured number falls inside the stated range.
By their numbers in this assay, from the lowest: compounds 3, 1, 4 and 2 (each within the scatter of the next, the first and the last beyond it).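

In this assay, for the compounds shown here, the one step that keeps the chain unchanged, a 2.3-fold higher number from compound 3 to compound 4 (0.35 log units; beyond the scatter), has (4-fluorophenyl)carbonyl in place of phenylsulfonyl on the amine nitrogen, and it shows that a change on this nitrogen can move the number modestly beyond the scatter. The other two steps, a 1.6-fold higher number from compound 1 to compound 4 (0.20 log units; within the scatter) and a 1.0-fold lower number from compound 2 to compound 4 (0.01 log units; within the scatter), change the chain length and the sulfonyl-to-carbonyl link together, and both stay within the scatter, so compound 4 cannot be told apart from compound 1 or compound 2 here. Nothing measured here explains why the number moves in one of these steps and not in the others.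

From the compounds shown here alone, the step from compound 3 changes the carbonyl and the fluoro together, so their separate shares remain unknown. Going by these compounds, how a urea or a still longer chain would behave in this place also stays open.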